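Compound 3 to compound 4: change on a carbonyl carbon

This account rests on a few compounds, and the source may have more. Where it says the series, first, only, none or still open, it means among the compounds named here.

Measured so far in a toxicity assay on THP-1 cells (Homo sapiens) for inhibition; on this read-out higher numbers stand for lower toxicity in this test and lower numbers for higher toxicity in this test:
- Compound 1 `COc1ccc(-c2cnc(NC(=O)C3CCNCC3)n2C)cc1` gives > 100000 nM as a limit
- Compound 2 `COc1ccc(-c2cnc(NC(=O)c3cccnc3)n2C)cc1` gives > 100000 nM as a limit
- Compound 3 `COc1ccc(-c2cnc(NC(=O)c3ccco3)n2C)cc1` gives > 100000 nM as a limit

Compound 3 therefore has no number, only a limit. It shares that position with the other two compounds (the limit of > 100000 nM in this assay, at which 3 of the 3 values shown sit). The next compound, compound 4 `COc1ccc(-c2cnc(NC(=O)c3cccc(O)c3)n2C)cc1`, carries 3-hydroxyphenyl in place of furan-2-yl on a carbonyl carbon.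

Three measured changes at this same carbonyl carbon bear on the step. They are a step that the two limits leave unreadable from compound 2 to compound 3 and a step that the two limits leave unreadable from compound 1 to compound 3 and a step that the two limits leave unreadable from compound 1 to compound 2 and none of them gives a size to carry over. Piperidin-4-yl, pyridin-3-yl and furan-2-yl all end at the same limit, so no step of readable size is expected in this assay and the most likely report is again a limit. Should a number appear, it is expected on the side of higher toxicity in this test. The estimated step is a number no higher from compound 3 to compound 4 (the limit leaves the size open) and this rests on very little. For compound 4 the expected value is 100000 nM with an estimated range from 40000 nM to 100000 nM in this read-out.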

Compound 4, half-maximal cytotoxic concentration: > 100000 nM
Compound 4: no number, only a limit; the forecaster's own chance of this, stated with the estimate: 80%; the middle value lies on the limit itself.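

In this assay compound 4 gives > 100000 nM as a limit and not a number. Its steps from compound 1, compound 2 and compound 3 therefore cannot be read, and no new step size follows. The compounds shown leave open whether any group on this carbonyl carbon gives a number in this assay and how large a step would be.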